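Bicyclic Amines: Cytotoxicity Notes Ahead of Compound 4

A few compounds are considered here, and "the series" means these few. Any claim that something is new, unique, unknown or untested is made for them only; others in the source may bear on it.

Measured so far:
compound 1 `C[C@H]1[C@H](N)C[C@@H]2C[C@H]1C2(C)C` — > 300000 nM
compound 2 `C[C@H]1[C@H](CN)C[C@@H]2C[C@H]1C2(C)C` — > 300000 nM
compound 3 `CC1(C)[C@@H]2CC[C@@]1(C)[C@@H](CN)C2` — > 300000 nM

The read-out is an ADME assay on MDCK cells (Canis lupus familiaris) for cytotoxicity, read by CCK-8 assay, with a stated time of 72 h; on this read-out lower numbers stand for higher toxicity in this test and higher numbers for lower toxicity in this test. Every value shown there is a limit of the assay and not a number. Compound 1 sits at its limit with > 300000 nM. Compound 2 likewise sits at a limit with > 300000 nM. Compound 3 stands at the same limit with > 300000 nM, so nothing separates it from the other two; all three share (the limit of > 300000 nM in this assay, at which 3 of the 3 values shown sit). Within the data shown here, the one measured step, a step that the two limits leave unreadable from compound 1 to compound 2, is unreadable, since both ends are limits.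

Compound 4 `C[C@@H](N)[C@H]1C[C@H]2CC[C@]1(C)C2(C)C` is not yet measured in this assay. It differs from compound 3 by methyl in place of hydrogen on a saturated chain carbon bound to an amine nitrogen and a saturated ring carbon. Among the measured compounds shown here, no measured step concerns a methyl in place of hydrogen on a saturated chain carbon bound to an amine nitrogen and a saturated ring carbon, and the only measured step of any kind is unreadable, so there is no readable step to lean on.

The expectation therefore rests on the limit shared by all three compounds. Compound 4 is expected to report a limit as well, estimated at 400000 nM with a range from 150000 nM to 1200000 nM. The step that the limit leaves unreadable from compound 3 to compound 4 is expected to be none beyond the scatter, most likely unreadable.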

Compound 4, minimum cytotoxic concentration: > 300000 nM
Compound 4 ended at the assay's limit (the forecaster's own chance of this, stated with the estimate: 85%); the middle value does not contradict the limit.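

In this assay no new step can be read, since compound 3 and compound 4 both sit at a limit of the assay and not at a number. What stays open is the concentration at which any of the four compounds becomes toxic in this test, and whether their structural differences matter: the limit of > 300000 nM in this assay, at which 4 of the 4 values shown sit.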